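This account rests on a few compounds, and the source may have more. Where it says the series, first, only, none or still open, it means among the compounds named here.

Compound 2 `O=c1[nH]c(NCCO)nc(-c2ccccc2)c1Cc1c(O)ccc2ccccc12` is the weaker of the two measured compounds in a functional assay on EJ cells (Homo sapiens) for antiproliferative activity, read by MTT assay, with a stated time of 3 h; a lower number here means a stronger inhibitor, a higher number a weaker inhibitor: compound 2 gives 282000 nM, whereas compound 1 `CCCCNc1nc(-c2ccccc2)c(Cc2c(O)ccc3ccccc23)c(=O)[nH]1` gives 24500 nM. Within the data shown here, the only step between measured compounds runs from compound 1 to compound 2, where a hydroxy replaces an ethyl on a saturated chain carbon, two bonds along the chain from a nitrogen on an aromatic ring, and it reads a 12-fold higher number from compound 1 to compound 2 (1.06 log units; beyond the scatter). Compound 3 `O=c1[nH]c(Nc2ccc(O)cc2)nc(-c2ccccc2)c1Cc1c(O)ccc2ccccc12` is not yet measured. It differs from compound 2 in one place: 4-hydroxyphenyl in place of 2-hydroxyethyl on a nitrogen on an aromatic ring. No measured step covers the exchange of a chain for an aromatic ring at this nitrogen, so the expectation rests on the hydroxyethyl compound 2 standing well behind the butyl compound 1 in this assay, shown by a 12-fold higher number from compound 1 to compound 2 (1.06 log units; beyond the scatter), and on compound 3 carrying a larger, ring-bearing group on the same nitrogen. A step back toward the range of compound 1 is expected, and compound 3 is estimated at 60000 nM, within 15000 nM to 250000 nM, which means an expected step of a 4.7-fold lower number from compound 2 to compound 3 (0.67 log units; beyond the scatter) from compound 2 to compound 3.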

Compound 3, half-maximal inhibitory concentration: 90900 nM
The estimate for compound 3 lay 1.5-fold (0.18 log units) below the measured number; measured number inside the range.
By their numbers in this assay, from the lowest: compound 1; then compound 3; then compound 2.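

In this assay, the nitrogen on an aromatic ring accepts a ring-bearing group as well as a chain, and the two groups that carry a hydroxy do not read alike: 4-hydroxyphenyl in place of 2-hydroxyethyl gives a 3.1-fold lower number from compound 2 to compound 3 (0.49 log units; beyond the scatter). A hydroxy in the group on this nitrogen therefore does not fix the number on its own, and what carries that hydroxy also counts among these compounds. The recovery is only partial, as 4-hydroxyphenyl in place of butyl gives a 3.7-fold higher number from compound 1 to compound 3 (0.57 log units; beyond the scatter), which leaves the butyl group with the lowest number of the three, and nothing available here explains either step.

On these data alone, what a plain phenyl or a benzyl group would give on this nitrogen remains open, and with it how much of the step belongs to the ring and how much to its hydroxy. Also open, as far as these compounds go, is whether a 4-hydroxybutyl group or an aminoethyl group would read closer to the butyl group or to the 2-hydroxyethyl group.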